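Fluoro to Nitro: Expected Effect on Cell Growth Inhibition

The compounds below may be only part of what the source reports. "The series", "measured", "known", "first", "only" and "open" are said of these compounds alone.

Measured compounds, all in a functional assay on MCF7 cells (Homo sapiens) for cytotoxicity, read by MTT assay, with a stated time of 48 h; a lower number here means a stronger inhibitor, a higher number a weaker inhibitor:
compound 1 `O=C(CSc1nnc(-c2ccncc2)o1)N/N=C/c1ccc(Cl)cc1` gives 15300 nM
compound 2 `O=C(CSc1nnc(-c2ccncc2)o1)N/N=C/c1ccc(O)cc1` gives 11700 nM
compound 3 `O=C(CSc1nnc(-c2ccncc2)o1)N/N=C/c1ccccc1F` gives 21800 nM

Compound 3 has the highest of the three numbers, but the gaps are small: a 1.4-fold higher number from compound 1 to compound 3 (0.15 log units; within the scatter) and a 1.9-fold higher number from compound 2 to compound 3 (0.27 log units; within the scatter). The remaining step, a 1.3-fold lower number from compound 1 to compound 2 (0.12 log units; within the scatter), is also within the scatter, so these three compounds cannot be ranked against one another on the numbers in hand.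

Compound 4 `O=C(CSc1nnc(-c2ccncc2)o1)N/N=C/c1ccccc1[N+](=O)[O-]` differs from compound 3 in one place: nitro in place of fluoro on an aromatic carbon. Within the data shown here, no measured step swaps one group for another at this position. The nearest case, a 1.3-fold lower number from compound 1 to compound 2 (0.12 log units; within the scatter), exchanged groups on an aromatic carbon and stayed within the scatter, and the two steps that both moved and changed the group did the same. Nothing measured here points to a shift beyond the scatter in this assay in either direction, so the expected step is a 1.1-fold lower number from compound 3 to compound 4 (0.04 log units; within the scatter). Compound 4 is therefore estimated at 20000 nM, with an expected range from 8000 nM to 50000 nM.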

Compound 4, half-maximal inhibitory concentration: 35600 nM
Compound 4: the middle estimate sits 1.8-fold (0.25 log units) below what was measured; low and high end bracket the measured number.
By their numbers in this assay, from the lowest: compounds 2, 1, 3 and 4 (each within the scatter of the next, the first and the last beyond it).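

In this assay the swap on this aromatic carbon, ortho to a large group, gives a 1.6-fold higher number from compound 3 to compound 4 (0.21 log units; within the scatter) even though nitro brings three heavy atoms and two hydrogen-bond acceptors where fluoro had one heavy atom and none. Among these compounds, compound 4 is nevertheless the only compound here with steps beyond the scatter, namely a 3.0-fold higher number from compound 2 to compound 4 (0.48 log units; beyond the scatter) and a 2.3-fold higher number from compound 1 to compound 4 (0.37 log units; beyond the scatter) and both are modest. Each of these two steps changes the group and its place on the ring together, so neither change can be credited on its own.

From the compounds shown here alone, it remains open how an amine or a carboxylic acid on this same carbon would compare with fluoro and nitro, and whether nitro would give a similar number at the ring place held by the chloro of compound 1. Nothing available here explains why any of these numbers differ.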